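From a Chlorobenzyl to an Ethoxybenzyl Amide

The source may report more compounds than this note shows. Statements on the series, on what has been measured and on what is new or still open speak of the compounds shown alone.

Of the compounds shown here, three that share one core have been tested in a functional assay on A2780 cells (Homo sapiens) for antiproliferative activity, read by resazurin assay, with a stated time of 72 h; on this read-out lower numbers stand for stronger inhibition and higher numbers for weaker inhibition. Compound 2 `CN(Cc1ccccc1Cl)C(=O)c1cc2c(Cc3ccccc3)n[nH]c2cc1O` gives 1100 nM, the lowest of the two numbers obtained. Compound 3 `CN(Cc1cccc(Br)c1)C(=O)c1cc2c(Cc3ccccc3)n[nH]c2cc1O` gives 7100 nM. Compound 1 `CCCN(C)C(=O)c1cc2c(Cc3ccccc3)n[nH]c2cc1O` reaches only (the limit of > 10000 nM in this assay, at which 1 of the 3 values shown sits), so for compound 1 the reading of > 10000 nM is a limit and not a number.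

Two steps describe how the group on the amide-type nitrogen matters. Replacing the ethyl of compound 1 by a 2-chlorophenyl brings an at least 9.0-fold lower number from compound 1 to compound 2 (0.95 log units; beyond the scatter), while moving from compound 2 to compound 3 brings a 6.5-fold higher number from compound 2 to compound 3 (0.81 log units; beyond the scatter); the related step of an at least 1.4-fold lower number from compound 1 to compound 3 (0.14 log units; that floor lies within the scatter) cannot be placed with confidence.

Compound 4 `CCOc1ccc(CN(C)C(=O)c2cc3c(Cc4ccccc4)n[nH]c3cc2O)cc1` is not yet measured. It differs from compound 2 in one place: 4-ethoxyphenyl in place of 2-chlorophenyl on a saturated chain carbon bound to an amide-type nitrogen. Among the measured compounds shown here, the one measured step that changes a substituted phenyl for another, from compound 2 to compound 3, made the number clearly worse, and there is no step that tests an alkoxy group. Compound 4 is therefore expected to lie on the weaker side of compound 2, with an estimated step of a 3.6-fold higher number from compound 2 to compound 4 (0.56 log units; beyond the scatter). Compound 4 is estimated at 4000 nM, with a range from 1000 nM to 15000 nM.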

Compound 4, half-maximal inhibitory concentration: 3200 nM
Estimate against measurement, compound 4: 1.3-fold (0.10 log units) above; the range from low to high includes it.
By their numbers in this assay, from the lowest: compound 2; then compound 4; then compound 3. At a limit, above all of these: compound 1.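

In this assay, putting 4-ethoxyphenyl in place of 2-chlorophenyl on a saturated chain carbon bound to an amide-type nitrogen gives a 2.9-fold higher number from compound 2 to compound 4 (0.46 log units; beyond the scatter), so this first ring with an oxygen-linked chain instead of a halogen does not match the 2-chlorophenyl ring. It still does better than the other halogen-bearing ring, with a 2.2-fold lower number from compound 3 to compound 4 (0.35 log units; beyond the scatter), which places the 4-ethoxyphenyl ring between the two halogen-bearing rings and shows that a halogen is not needed for activity at this place. Replacing the ethyl with the same ring gives an at least 3.1-fold lower number from compound 1 to compound 4 (0.49 log units; beyond the scatter), a step that counts only as a floor and, unlike the floor for compound 3, lies beyond the scatter, with the reading for compound 1 being a limit and not a number: the limit of > 10000 nM in this assay, at which 1 of the 4 values shown sits.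

Each of the three rings differs from the others in both the group it carries and where that group sits, so these two kinds of change remain unseparated. Going by these compounds, what a plain phenyl ring, or a ring carrying an amine or a carboxylic acid, would give at this place remains open.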